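This account rests on a few compounds, and the source may have more. Where it says the series, first, only, none or still open, it means among the compounds named here.

In an assay on isolated protein for binding affinity to corticotropin-releasing factor receptor 1 (Homo sapiens) (on this read-out higher numbers stand for weaker inhibition and lower numbers for stronger inhibition), compound 1 `CCN(c1nc(C)cc(C)n1)c1ccc(C(C)(C)C)cc1Br` gives only a limit, > 100 nM, a bound of the assay rather than a measured number (the limit of > 100 nM in this assay, at which 1 of the 2 values shown sits). Compound 2 `CCN(c1nc(C)nc(N(CC2CC2)CC2CC2)n1)c1ccc(N(C)C)cc1C(F)(F)F`, built on a different core, gives 5 nM in this assay. Compound 3 `CCN(c1nc(C)cc(C)n1)c1ccccc1Br` differs from compound 1 in one place: hydrogen in place of tert-butyl on an aromatic carbon. For the measured compounds named here, no measured pair shows this change, so its direction is open. Compound 3 is expected to stay weak, the step that the limit leaves unreadable from compound 1 to compound 3 being expected to fall within the scatter or toward weaker inhibition. Compound 3 is estimated at 300 nM, with a range from 100 nM to 3000 nM.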

Compound 3, inhibition constant: > 1000 nM
Compound 3: no number, only a limit; the forecaster's own chance of this, stated with the estimate: 75%; middle value at least 3.3-fold (0.52 log units) away from the limit.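

Compound 1 and compound 3 both give only limits in this assay, and no step can be read between them. The compounds shown leave open the size and direction of the change from tert-butyl to hydrogen.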